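The source may hold more compounds than are shown below. What is called first, only, known or untested is meant among the compounds shown, and "the series" means these compounds.

Measured in a toxicity assay on HS27 cells (Homo sapiens) for cytotoxicity, with a stated time of 20 h; a higher number here means that more compound is tolerated, a lower number that less compound is tolerated:
compound 1 `Cc1ccc(NC(=O)COc2ccc3cc(/C=C4/SC(=O)NC4=O)ccc3c2)cc1`: 40200 nM
compound 2 `O=C(COc1ccc2cc(/C=C3/SC(=O)NC3=O)ccc2c1)Nc1ccc(Br)cc1F`: 57000 nM

Within the data shown here, compound 2 stands level with the only other measured compound, since a 1.4-fold higher number from compound 1 to compound 2 (0.15 log units; within the scatter) lies within the scatter. Compound 3 `O=C(COc1ccc2cc(/C=C3/SC(=O)NC3=O)ccc2c1)Nc1c(F)cc(F)cc1Br` differs from compound 2 by 2-bromo-4,6-difluorophenyl in place of 4-bromo-2-fluorophenyl on an amide-type nitrogen. Among the measured compounds shown here, the one measured step, a 1.4-fold higher number from compound 1 to compound 2 (0.15 log units; within the scatter), also changed the group on that nitrogen, so it alone bears on this change. No step beyond the scatter is therefore expected in this assay. The expected step is a 1.1-fold lower number from compound 2 to compound 3 (0.06 log units; within the scatter). For compound 3 the estimated value is 50000 nM, within an expected range of 24000 nM to 100000 nM.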

Compound 3, half-maximal cytotoxic concentration: 39900 nM
Estimate against measurement, compound 3: 1.3-fold (0.10 log units) above; the measured number falls inside the stated range.
By their numbers in this assay, from the lowest: compounds 3, 1 and 2 (each within the scatter of the next).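

In this assay, 2-bromo-4,6-difluorophenyl on the amide-type nitrogen gives a 1.4-fold lower number from compound 2 to compound 3 (0.15 log units; within the scatter) and a 1.0-fold lower number from compound 1 to compound 3 (0.00 log units; within the scatter), so both steps stay inside the scatter. Among these compounds, all three substituted phenyl groups on this nitrogen now read level, which extends what the single earlier step could show. Nothing available accounts for this flat picture.

Going by these compounds, whether a carboxylic acid or an amine-bearing chain on this nitrogen would also read level remains open. So does the effect of changes elsewhere on the shared core.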